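A few compounds are considered here, and "the series" means these few. Any claim that something is new, unique, unknown or untested is made for them only; others in the source may bear on it.

Measured in a functional assay on SK-N-SH cells (Homo sapiens) for cytotoxicity, read by MTT assay, with a stated time of 48 h; on this read-out lower numbers stand for stronger inhibition and higher numbers for weaker inhibition:

- compound 1 `O=C1Nc2ccccc2C1(c1c[nH]c2ccccc12)c1c[nH]c2ccccc12` gives 11300 nM
- compound 2 `COc1ccc2[nH]cc(C3(c4c[nH]c5ccc(OC)cc45)C(=O)Nc4ccccc43)c2c1` gives 3900 nM
- compound 3 `O=C1Nc2ccccc2C1(c1c[nH]c2ccc(Br)cc12)c1c[nH]c2ccc(Br)cc12` gives 13200 nM

Compound 1 stands second highest of the three numbers, although its value lies within the usual scatter of the value of compound 3. Compound 2 shows a lower number than compound 1, and that gap lies beyond the scatter, so compound 2 inhibits more strongly in this assay than compound 1 does.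

The next compound to be tested is compound 4 `O=C1Nc2ccc(F)cc2C1(c1c[nH]c2ccccc12)c1c[nH]c2ccccc12`, in which fluoro takes the place of hydrogen on an aromatic carbon of compound 1 (fluoro in place of hydrogen on an aromatic carbon). For the measured compounds named here, no two measured compounds differ in one place only, so this change has no direct precedent in the data. Compound 3, which also bears halogen but on other parts of the molecule, gives 13200 nM and stays within the scatter of compound 1. On that slender basis, no step beyond the scatter is expected in this assay, perhaps a slightly lower number at most. The estimated step is a 1.3-fold lower number from compound 1 to compound 4 (0.10 log units; within the scatter) and is expected to remain within the scatter. For compound 4 the expected value is 9000 nM, with an estimated range from 3500 nM to 22000 nM.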

Compound 4, half-maximal inhibitory concentration: 67300 nM
Estimate against measurement, compound 4: 7.5-fold (0.87 log units) below; measured number outside the range, above it.
By their numbers in this assay, from the lowest: compound 2; then compounds 1 and 3 (each within the scatter of the next); then compound 4.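

In this assay, replacing hydrogen with fluoro on an aromatic carbon of the core gives a 6.0-fold higher number from compound 1 to compound 4 (0.77 log units; beyond the scatter), the first effect in this set that can be read for a single change, and it lies beyond the scatter. For the compounds shown here, this shows that the position, on the six-membered aromatic ring of carbon only, is not indifferent to substitution: a single fluorine atom in place of hydrogen is enough to weaken inhibition in this cell assay, which the earlier compounds, none of them differing from another in one place only, could not show. The data at hand offer no measurement that would explain this step.

The compounds shown leave open whether this weakening is particular to fluoro or extends to other groups on the same carbon, such as chloro, an amine or a carboxylic acid. They also leave open whether fluoro would have a similar effect on other aromatic carbons of the core, since this single step describes only one position and one replacement.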